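A few compounds are considered here, and "the series" means these few. Any claim that something is new, unique, unknown or untested is made for them only; others in the source may bear on it.

Measured so far:
compound 1 `COc1ccccc1-c1nc(Cc2c[nH]c3ccccc23)no1`: 42200 nM
compound 2 `COc1ccc(-c2nc(Cc3c[nH]c4ccccc34)no2)cc1`: > 50000 nM

In an ADME assay on cells (Splenocyte, Mus musculus, strain BALB/c) for cytotoxicity, read by CCK-8 assay, with a stated time of 48 h (on this read-out lower numbers stand for higher toxicity in this test and higher numbers for lower toxicity in this test), compound 1 `COc1ccccc1-c1nc(Cc2c[nH]c3ccccc23)no1` gives 42200 nM. Compound 2 `COc1ccc(-c2nc(Cc3c[nH]c4ccccc34)no2)cc1` in this assay gives > 50000 nM, and this is a limit of the assay, not a number. On the numbers shown, compound 2 stands at the limit of > 50000 nM in this assay, at which 1 of the 2 values shown sits, so its position cannot be set more closely; its value and that of compound 1 may well lie within the usual scatter of each other, and no order between the two is claimed. Among the compounds with values here, no pair of measured compounds differing in one place is available, so no measured step supports the next change.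

Compound 3 `COc1ccc(-c2nc(Cc3c[nH]c4ccccc34)no2)c(OC)c1` differs from compound 2 by methoxy in place of hydrogen on an aromatic carbon. With nothing measured for this kind of change in the series, the step is expected to stay within the scatter in this assay, with no firm direction. Compound 3 is therefore expected to give about 50000 nM in this assay, within 25000 nM to 100000 nM. The step from compound 2 to compound 3 is expected to be a number no higher from compound 2 to compound 3 (the limit leaves the size open), and a further limit report is thought likely.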

Compound 3, half-maximal cytotoxic concentration: 9300 nM
Compound 3: middle estimate off by 5.4-fold (0.73 log units), on the high side; measured number outside the range, below it.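

In this assay, within the data shown here, methoxy in place of hydrogen on an aromatic carbon, ortho to a large group and meta to a methoxy group, is the first change with a step beyond the scatter: an at least 5.3-fold lower number from compound 2 to compound 3 (0.73 log units; beyond the scatter). The same kind of change, starting from the other compound with a single methoxy group, gives a 4.5-fold lower number from compound 1 to compound 3 (0.66 log units; beyond the scatter), so both steps point the same way, towards higher toxicity in this test. The step from compound 2 starts from a limit of the assay, not a number, and its full size stays open: the limit of > 50000 nM in this assay, at which 1 of the 3 values shown sits.

Whether the lower number follows from methoxy at this one place or from the presence of two methoxy groups on the ring stays open, and these three compounds give no cause for the step. Also open, going by these compounds, is how an amine, a carboxylic acid or a longer chain such as ethoxy on the same aromatic carbon would read in this assay.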